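This account rests on a few compounds, and the source may have more. Where it says the series, first, only, none or still open, it means among the compounds named here.

Measured so far in a functional assay on A549 cells (Homo sapiens) for antiproliferative activity, read by MTT assay, with a stated time of 24 h; on this read-out higher numbers stand for weaker inhibition and lower numbers for stronger inhibition:
compound 1 `Cc1ccc(C)c(S(=O)(=O)n2c(-c3cn(-c4ccccc4)nc3-c3ccc(C(F)(F)F)cc3)nc3ccccc32)c1`: 150 nM
compound 2 `O=[N+]([O-])c1ccc(S(=O)(=O)n2c(-c3cn(-c4ccccc4)nc3-c3ccc(C(F)(F)F)cc3)nc3ccccc32)cc1`: 790 nM
compound 3 `O=S(=O)(c1ccc(F)cc1)n1c(-c2cn(-c3ccccc3)nc2-c2ccc(C(F)(F)F)cc2)nc2ccccc21`: 1740 nM

Compound 3 has the highest number of the three, and its steps to both others lie beyond the scatter. The next compound, compound 4 `O=S(=O)(c1ccc(Cl)cc1)n1c(-c2cn(-c3ccccc3)nc2-c2ccc(C(F)(F)F)cc2)nc2ccccc21`, differs from it as follows: chloro in place of fluoro on an aromatic carbon. This places chloro in place of fluoro on an aromatic carbon, para to a large group.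

Going by the values given here, no measured pair shows this exact change. The closest evidence is a 2.2-fold higher number from compound 2 to compound 3 (0.34 log units; beyond the scatter), a modest step with fluoro in place of nitro. The step of a 12-fold higher number from compound 1 to compound 3 (1.06 log units; beyond the scatter) is large, but it exchanges the whole 2,5-dimethylphenyl group for 4-fluorophenyl, so it bears on the change less directly.

With only these steps as a guide, a modest move toward a lower number is expected in this assay, though no change beyond the scatter remains possible. The expected step is a 2.2-fold lower number from compound 3 to compound 4 (0.34 log units; beyond the scatter). For compound 4 the estimated value is 800 nM, with an expected range from 280 nM to 2000 nM.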

Compound 4, half-maximal inhibitory concentration: 2560 nM
For compound 4 the middle estimate is 3.2-fold (0.51 log units) below the measured one; the whole stated range lies below it.
By their numbers in this assay, from the lowest: compound 1; then compound 2; then compounds 3 and 4 (each within the scatter of the next).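

In this assay, chloro in place of fluoro on an aromatic carbon, para to a large group, gives a 1.5-fold higher number from compound 3 to compound 4 (0.17 log units; within the scatter), so this read-out does not separate the two halogens at this position. The chloro compound also stands clearly apart from the other two sulfonyl aryl groups, with a 3.2-fold higher number from compound 2 to compound 4 (0.51 log units; beyond the scatter) for the exchange with nitro and a 17-fold higher number from compound 1 to compound 4 (1.23 log units; beyond the scatter) for the exchange of the whole 4-chlorophenyl group with 2,5-dimethylphenyl, so in these compounds the larger differences come with those exchanges and not with the halogen swap. Nothing available here accounts for these differences.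

On these data alone, it remains open how a methoxy group or an amine on this same carbon would read in this assay. Also open, as far as these compounds go, is whether a phenyl ring carrying a single methyl group would keep the low number of the 2,5-dimethylphenyl compound.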